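The source may report more compounds than this note shows. Statements on the series, on what has been measured and on what is new or still open speak of the compounds shown alone.

Compound 2 `OC1CCc2cccc(Nc3nc(Br)c(-c4ccc(C(F)(F)F)cc4)o3)c2C1` and compound 1 `Cc1cccc(-c2cnc(Nc3cccc4c3CC(O)CC4)o2)c1` share the same core and the same amine side, and differ in both substituents on the five-membered ring. Within the data shown here, in an in vitro functional assay on cells for antagonist activity at transient receptor potential cation channel subfamily V member 1 (Homo sapiens), read by FLIPR and calcium flux (a higher number here means a weaker inhibitor, a lower number a stronger inhibitor), compound 2 gives 9 nM, the lowest of the two numbers known, while compound 1 gives 157 nM, a gap that lies beyond the scatter. Among the measured compounds shown here, no step between measured compounds that differ in one place is available, so the pair shows only that the two substitution patterns sit far apart in this assay. Compound 3 `OC1CCc2cccc(Nc3nc(-c4ccc(F)cc4)c(-c4ccc(C(F)(F)F)cc4)o3)c2C1` keeps the rest of compound 2 unchanged and alters one place: 4-fluorophenyl in place of bromo on an aromatic carbon. The size of this exchange cannot be read from the two numbers at hand. The step from compound 2 to compound 3 is expected to be a 1.7-fold higher number from compound 2 to compound 3 (0.22 log units; within the scatter), a small change close to the scatter. For compound 3 in this assay the estimate is 15 nM, with a range of 4 nM to 60 nM.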

Compound 3, half-maximal inhibitory concentration: 1.3 nM
For compound 3 the middle estimate is 12-fold (1.06 log units) above the measured one, and the stated range ends above it.
By their numbers in this assay, from the lowest: compound 3; then compound 2; then compound 1.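

In this assay the exchange of bromo for 4-fluorophenyl gives a 6.9-fold lower number from compound 2 to compound 3 (0.84 log units; beyond the scatter) and so shows that this aromatic carbon next to the ring nitrogen accepts an aromatic ring of 7 heavy atoms in place of a single bromine, with a gain rather than a loss. Among these compounds, this is the first step that isolates one place, whereas the gap between compound 1 and compound 2 mixed both substituents on the five-membered ring. Nothing measured here explains the gain.

On these data alone, how an unsubstituted phenyl, a methyl or an amine at this carbon would compare with 4-fluorophenyl remains open, as does any separate contribution of the fluorine. As far as these compounds go, the step is known only with the rest of compound 2 held fixed, so its size alongside the other substituent of compound 1 is also open.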